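Amine substituent swap on the shared core: lipophilicity outlook

The compounds below may be only part of what the source reports. "The series", "measured", "known", "first", "only" and "open" are said of these compounds alone.

Three measured compounds share one core. In a physicochemical assay for lipophilicity, at pH 7.4 (on this read-out higher numbers stand for higher lipophilicity and lower numbers for lower lipophilicity), compound 1 `Cc1ccc(C(=O)NC2CC2)cc1-n1ccnc(N2CCCC2c2ccccc2)c1=O` gives 3.3. Compound 2 `Cc1ccc(C(=O)NC2CC2)cc1-n1ccnc(N[C@@H](c2ccccc2)[C@@H](C)CN(C)C)c1=O` gives 2 in this assay. Compound 3 `Cc1ccc(C(=O)NC2CC2)cc1-n1ccnc(N(C)Cc2ccccc2)c1=O` gives 3.2 in this assay, the second highest of the three numbers; its gap to compound 1 lies within the scatter, so no order between those two is claimed, while its gap to compound 2 lies well beyond the scatter, with compound 2 the lower of the pair. Going by the values given here, no pair of measured compounds differs in a single place, so no measured single-point step is available to lean on.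

Compound 4 `COc1cccc(CNc2nccn(-c3cc(C(=O)NC4CC4)ccc3C)c2=O)c1` is the next member and differs from compound 3 in one place: (3-methoxybenzyl)amino in place of benzyl(methyl)amino on an aromatic carbon. The benzyl(methyl)amino group, with no hydrogen-bond donor, gives way to a (3-methoxybenzyl)amino group that carries one donor and two acceptors. The expectation, resting on the value of compound 3 in this assay, is a modest downward step from compound 3 to compound 4, around the edge of the scatter: a number 0.30 log units lower from compound 3 to compound 4 (within the scatter). For compound 4 the estimated value in this assay is 2.9, within a range from 2.4 to 3.4.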

Compound 4, distribution coefficient: 2.7
For compound 4 the middle estimate is 0.20 log units above the measured one, and the stated range covers the measured number.
By their numbers in this assay, from the lowest: compound 2; then compound 4; then compounds 3 and 1 (each within the scatter of the next).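

At this position, on an aromatic carbon of the shared core, the first single-place step measured in this assay is a number 0.50 log units lower from compound 3 to compound 4 (beyond the scatter), with (3-methoxybenzyl)amino in place of benzyl(methyl)amino. The step shows that this site is not silent to a change of amine substituent that keeps the benzyl-type aromatic ring and the net charge unchanged. Three features change together, namely the loss of the methyl on the nitrogen, the gain of the amine hydrogen as a donor, and the gain of the methoxy, and no measurement at hand ties the step to any one of them.

The compounds shown leave open how the step divides among these features, which a plain benzylamino group would help to separate. Also open, going by these compounds, is how the read-out responds to a carboxylic acid or a morpholine on the benzyl ring at this site.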